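Notes on the step from compound 2 to compound 3

A few compounds are considered here, and "the series" means these few. Any claim that something is new, unique, unknown or untested is made for them only; others in the source may bear on it.

Measured in a functional assay on HepG2 cells (Homo sapiens) for inhibition, read by MTT assay, with a stated time of 48 h; on this read-out lower numbers stand for stronger inhibition and higher numbers for weaker inhibition:
- compound 1 `Brc1ccc(CSc2nnc(-c3ccncc3)n2-c2ccccc2)cc1` gives 12900 nM
- compound 2 `Fc1cccc(F)c1CSc1nnc(-c2ccncc2)n1-c1ccccc1` gives only a limit of the assay, > 50000 nM

Compound 2 stands at the limit of > 50000 nM in this assay, at which 1 of the 2 values shown sits, so it has a limit and no number. Compound 3 `c1ccc(CSc2nnc(-c3ccncc3)n2-c2ccccc2)cc1` has not yet been measured. It differs from compound 2 by phenyl in place of 2,6-difluorophenyl on a saturated chain carbon bound to a sulfur, which puts phenyl in place of 2,6-difluorophenyl on a saturated chain carbon bound to a sulfur. For the measured compounds named here, one measured step bears on this place: an at least 3.8-fold higher number from compound 1 to compound 2 (0.58 log units; beyond the scatter). Going by the values given here, that step has only a lower bound on its size, and no measured compound yet carries the plain phenyl. A modest fall in the number in this assay is therefore expected, with a result at the limit still possible. The expected change is an at least 2.2-fold lower number from compound 2 to compound 3 (0.35 log units; beyond the scatter). For compound 3 the estimated value is 22000 nM, with an expected range from 8000 nM to 60000 nM.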

Compound 3, half-maximal inhibitory concentration: 12900 nM
Beside the measured number, compound 3's estimate is 1.7-fold (0.23 log units) above it, within the range that was stated.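

In this assay, the plain phenyl gives a measured number where the 2,6-difluorophenyl does not, with an at least 3.8-fold lower number from compound 2 to compound 3 (0.58 log units; beyond the scatter), so among the compounds shown the weak read-out goes with the 2,6-difluorophenyl and not with the benzyl group as such. Against this, the bromo of compound 1 makes no visible difference, with no change at the digits printed from compound 1 to compound 3 (within the scatter), so the result for compound 1 owes nothing measurable to that halogen on this read-out. The entry for compound 2 is a limit and not a number, which leaves the step to it without an upper size: the limit of > 50000 nM in this assay, at which 1 of the 3 values shown sits.

Still open, from the compounds shown here alone, is whether a single fluoro on the phenyl, or an amine or a carboxylic acid in place of the bromo, would move the number in this assay. Also open, going by these compounds, is how a longer chain in place of the benzyl would read there.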